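This account rests on a few compounds, and the source may have more. Where it says the series, first, only, none or still open, it means among the compounds named here.

In a functional assay on MCF7 cells (Homo sapiens) for antiproliferative activity, read by sulforhodamine B assay, with a stated time of 48 h (on this read-out lower numbers stand for stronger inhibition and higher numbers for weaker inhibition), compound 1 `CCCN1CCN(c2ccc(S(=O)(=O)Oc3ccc(OC)cc3)cc2)C1=O` gives 20000 nM, and compound 2 `CCCN1CCN(c2ccc(S(=O)(=O)Oc3ccc(F)cc3)cc2)C1=O` gives 33000 nM. The change between them is fluoro in place of methoxy on an aromatic carbon, and it produced a 1.7-fold higher number from compound 1 to compound 2 (0.22 log units; within the scatter). Compound 3 `CCCCN1CCN(c2ccc(S(=O)(=O)Oc3cccc(OC)c3)cc2)C1=O` gives 490 nM in this assay; the difference between the core of compound 1 and the core of compound 3 is not broken down here. Compound 4 `CCCCN1CCN(c2ccc(S(=O)(=O)Oc3cccc(F)c3)cc2)C1=O` has not yet been measured. It differs from compound 3 by fluoro in place of methoxy on an aromatic carbon. Among the compounds with values here, this is the same kind of change as the one from compound 1 to compound 2, though the place is not identical: in compound 1 the group sits para to a large group, in compound 3 meta to a large group. Since the measured step was a 1.7-fold higher number from compound 1 to compound 2 (0.22 log units; within the scatter), the expected step is a 1.6-fold higher number from compound 3 to compound 4 (0.21 log units; within the scatter). Compound 4 is therefore estimated to give 800 nM in this assay, most likely between 300 nM and 2500 nM.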

Compound 4, half-maximal inhibitory concentration: 310 nM
The estimate for compound 4 lay 2.6-fold (0.41 log units) above the measured number; measured number inside the range.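

In this assay, fluoro in place of methoxy on the core of compound 3 gave a 1.6-fold lower number from compound 3 to compound 4 (0.20 log units; within the scatter). On both cores the swap left the number about where it was, and the two steps cannot be told apart: the same change on two cores in this assay, a 1.7-fold higher number (0.22 log units; within the scatter) from compound 1 to compound 2 and a 1.6-fold lower number (0.20 log units; within the scatter) from compound 3 to compound 4, 2.6-fold (0.42 log units) apart, within the scatter of two such steps

This does not show that the swap would be as quiet on every core in the series, as two pairs are too few to set a rule. Still open, from the compounds shown here alone, is whether other groups in the same place, such as chloro, an amine or a carboxylic acid, would move the number further. Also open, going by these compounds, is which part of the difference between the core of compound 1 and the core of compound 3 matters in this assay.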